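This account rests on a few compounds, and the source may have more. Where it says the series, first, only, none or still open, it means among the compounds named here.

In a functional assay on HepG2 cells (Homo sapiens) for inhibition, read by MTT assay, with a stated time of 48 h (a higher number here means a weaker inhibitor, a lower number a stronger inhibitor), compound 3 `COc1cc(-c2nnc(S)n2-c2ccc(N(C)C)cc2)cc(OC)c1OC` stands at > 60000 nM, which is a limit and not a number. Compound 2 `COc1ccc(-n2c(SC)nnc2-c2cc(OC)c(OC)c(OC)c2)cc1` reads > 60000 nM in this assay, also a limit. Compound 1 `COc1ccc(-n2c(S)nnc2-c2cc(OC)c(OC)c(OC)c2)cc1`, the only one of the three with a number, gives 57500 nM.

Compound 4 `COc1cc(-c2nnc(SC)n2-c2ccc(N(C)C)cc2)cc(OC)c1OC` differs from compound 3 by methyl in place of hydrogen on a sulfur. This change was measured once, as an at least 1.0-fold higher number from compound 1 to compound 2 (0.01 log units; that floor lies within the scatter). Dimethylamino in place of methoxy on an aromatic carbon gave an at least 1.0-fold higher number from compound 1 to compound 3 (0.01 log units; that floor lies within the scatter). Both steps stop at the limit of > 60000 nM in this assay, at which 2 of the 3 values shown sit, so neither gives a full size.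

No change beyond the scatter is expected in this assay, and the estimated size is a step that the limit leaves unreadable from compound 3 to compound 4. For compound 4 the estimate is 80000 nM, with an expected range from 45000 nM to 200000 nM.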

Compound 4, half-maximal inhibitory concentration: > 60000 nM
Compound 4 was reported as a limit; the forecaster's own chance of this, stated with the estimate: 85%; the middle value lies beyond the limit too.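

No step to compound 4 can be read from compound 2 or compound 3, since all three stop at the same limit: the limit of > 60000 nM in this assay, at which 3 of the 4 values shown sit.
On these data alone, the actual strengths of compound 2, compound 3 and compound 4 remain open.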